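Ester and carboxyphenyl variants on a shared lactone core

The compounds below may be only part of what the source reports. "The series", "measured", "known", "first", "only" and "open" are said of these compounds alone.

Measured so far, in an assay for displacement of a labelled ligand from protein kinase C delta type (Mus musculus), with a stated time of 30 min, in the presence of a further agent that is not named here; on this read-out higher numbers stand for weaker binding and lower numbers for tighter binding:
- compound 1 `CC(C)C(CC(=O)OCC1(CO)C/C(=C\c2cccc(C(=O)O)c2)C(=O)O1)C(C)C` gives 2100 nM
- compound 2 `CC(C)(C)C(=O)OCC1(CO)C/C(=C\c2ccc(C(=O)O)cc2)C(=O)O1` gives 1070 nM
- compound 3 `CC(C)C(CC(=O)OCC1(CO)C/C(=C\c2ccc(C(=O)O)cc2)C(=O)O1)C(C)C` gives 560 nM

Two changes are covered by the measured set. The ester change is seen once: a 1.9-fold higher number from compound 3 to compound 2 (0.28 log units; within the scatter), the change being (tert-butyl in place of 2-isopropyl-3-methylbutyl on a carbonyl carbon). The core change is seen once: a 3.8-fold lower number from compound 1 to compound 3 (0.57 log units; beyond the scatter); the two cores differ by 3-carboxyphenyl in place of 4-carboxyphenyl on a double-bonded chain carbon bound to a double-bonded ring carbon. Compound 1 carries the highest number of the three; its gap to compound 2 is within the scatter, its gap to compound 3 beyond it.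

Compound 4 `CC(C)(C)C(=O)OCC1(CO)C/C(=C\c2cccc(C(=O)O)c2)C(=O)O1` is not yet measured. It differs from compound 1 by tert-butyl in place of 2-isopropyl-3-methylbutyl on a carbonyl carbon. Within the data shown here, this is the same change as the one from compound 3 to compound 2, made at a place described in the same words, but on the core of compound 1 rather than that of compound 3. Among the measured compounds shown here, only one instance of this change is available, and its step lay within the scatter, so no effect beyond noise is established for it. For compound 4 the step of a 1.7-fold higher number from compound 1 to compound 4 (0.22 log units; within the scatter) is expected, resting on the measured change from compound 3 to compound 2 a 1.9-fold higher number from compound 3 to compound 2 (0.28 log units; within the scatter) applied to the value of compound 1 2100 nM. For the measured compounds named here, compound 4 is therefore estimated at 3500 nM, within 1500 nM to 8500 nM, the wide range reflecting that one step within scatter is the only guide.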

Compound 4, dissociation constant: 1210 nM
For compound 4 the middle estimate is 2.9-fold (0.46 log units) above the measured one, and the stated range ends above it.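

In this assay, tert-butyl in place of 2-isopropyl-3-methylbutyl on the 3-carboxyphenyl variant gives a 1.7-fold lower number from compound 1 to compound 4 (0.24 log units; within the scatter), and the comparison with the same change on the 4-carboxyphenyl variant reads: the same change on two cores in this assay, a 1.9-fold higher number (0.28 log units; within the scatter) from compound 3 to compound 2 and a 1.7-fold lower number (0.24 log units; within the scatter) from compound 1 to compound 4, 3.3-fold (0.52 log units) apart, beyond the scatter of two such steps

The change therefore does not carry from one core to the other as a fixed step, and a step read on one of these cores is a poor guide to the other. This does not show that the change has a real effect on either core, since each step taken alone lies within the scatter; only the gap between the two steps lies beyond it, and a single pair of cores gives neither a reason for that gap nor a rule for a further core.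

Still open, as far as these compounds go, is whether a third ester group, such as a longer straight chain or a chain carrying an amine, would show the same gap between the two cores. Also open, from the compounds shown here alone, is how either core would read with a nitrile or an amide on the phenyl ring in place of the carboxylic acid.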